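The compounds below may be only part of what the source reports. "The series", "measured", "known", "first", "only" and "open" are said of these compounds alone.

Measured in a functional assay on NCI-H460 cells (Homo sapiens) for cytotoxicity, read by MTT assay, with a stated time of 48 h; a lower number here means a stronger inhibitor, a higher number a weaker inhibitor:
- compound 1 `C=C1C(=O)O[C@H]2CC3=C[C@H](C/C(C)=C/[C@@H](OC(=O)c4ccc(C(F)(F)F)cc4)[C@H]12)OC3=O` gives > 10000 nM (a limit of the assay, not a number)
- compound 2 `C=C1C(=O)O[C@H]2CC3=C[C@H](C/C(C)=C/[C@@H](OC(=O)CC4CCCCC4)[C@H]12)OC3=O` gives 2000 nM
- compound 3 `C=C1C(=O)O[C@H]2CC3=C[C@H](C/C(C)=C/[C@@H](OC(=O)C4CC4)[C@H]12)OC3=O` gives 3000 nM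

Compound 3, at 3000 nM, sits level with compound 2 because a 1.5-fold higher number from compound 2 to compound 3 (0.18 log units; within the scatter) is within the scatter. Compound 4 `C=C1C(=O)O[C@H]2CC3=C[C@H](C/C(C)=C/[C@@H](OC(=O)CC(C)C)[C@H]12)OC3=O` differs from compound 3 by one change: isobutyl in place of cyclopropyl on a carbonyl carbon, with isobutyl in place of cyclopropyl on a carbonyl carbon. The closest measured precedent is that same step between compound 2 and compound 3, where exchanging one ring-bearing group without an aromatic ring for another moved nothing beyond the scatter. Replacing 4-(trifluoromethyl)phenyl counted for more: an at least 5.0-fold lower number from compound 1 to compound 2 (0.69 log units; beyond the scatter) and an at least 3.3-fold lower number from compound 1 to compound 3 (0.52 log units; beyond the scatter). Isobutyl is not aromatic, so no step beyond the scatter is expected in this assay. The expected change is small, an estimated 1.2-fold lower number from compound 3 to compound 4 (0.08 log units; within the scatter). For compound 4 the estimated value is 2500 nM, within an expected range of 1000 nM to 6000 nM.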

Compound 4, half-maximal inhibitory concentration: 3800 nM
Estimate against measurement, compound 4: 1.5-fold (0.18 log units) below; the measured number falls inside the stated range.
By their numbers in this assay, from the lowest: compounds 2, 3 and 4 (each within the scatter of the next). At a limit, above all of these: compound 1.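

In this assay, an open-chain group on this carbonyl carbon does as well as the ring-bearing ones, with a 1.3-fold higher number from compound 3 to compound 4 (0.10 log units; within the scatter) and a 1.9-fold higher number from compound 2 to compound 4 (0.28 log units; within the scatter), so a saturated ring is not needed here. The aromatic group remains the one that stands apart, with an at least 2.6-fold lower number from compound 1 to compound 4 (0.42 log units; beyond the scatter), and compounds 2, 3 and 4, all non-aromatic, stay together. Compound 1 carries a limit, not a number: the limit of > 10000 nM in this assay, at which 1 of the 4 values shown sits.

As far as these compounds go, whether an amine, a carboxylic acid or a longer chain here would give a clearly lower number remains open. So does whether plain phenyl, without trifluoromethyl, would behave like compound 1.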